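Methyl for carboxy on the sulfonyl aryl of compound 1

This account rests on a few compounds, and the source may have more. Where it says the series, first, only, none or still open, it means among the compounds named here.

Measured so far in a functional assay on K562 cells (Homo sapiens) for inhibition, read by trypan blue exclusion, with a stated time of 72 h; a higher number here means a weaker inhibitor, a lower number a stronger inhibitor:
- compound 1 `Cn1c(=O)c(S(=O)(=O)c2ccc(C(=O)O)cc2)cc2cnc(Nc3ccc4[nH]ccc4c3)nc21`: 5000 nM
- compound 2 `Cn1c(=O)c(S(=O)(=O)c2ccc(F)cc2F)cc2cnc(Nc3ccncn3)nc21`: 30000 nM
- compound 3 `Cn1c(=O)c(S(=O)(=O)c2ccccc2)cc2cnc(Nc3ccc4cc[nH]c4c3)nc21`: 10000 nM

Compound 1 has the lowest number of the three. Its gap to compound 3 falls within the scatter, so no order between these two can be read; its gap to compound 2 lies beyond the scatter, compound 2 giving the higher number. Compound 2 differs from compound 1 in more than one place, so nothing is attributed to a single change there.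

Compound 4 `Cc1ccc(S(=O)(=O)c2cc3cnc(Nc4ccc5[nH]ccc5c4)nc3n(C)c2=O)cc1` differs from compound 1 in one place: methyl in place of carboxy on an aromatic carbon. Going by the values given here, no measured pair isolates this change. Compound 3, which carries the unsubstituted ring at the same position, sits within the scatter of compound 1, which suggests that the group on this ring moves the number little. The step from compound 1 to compound 4 in this assay is therefore expected to be small, a 1.4-fold higher number from compound 1 to compound 4 (0.15 log units; within the scatter), not clearly beyond the scatter in either direction. Compound 4 is estimated at 7000 nM, with a range of 2500 nM to 20000 nM.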

Compound 4, half-maximal inhibitory concentration: 750 nM
Estimate against measurement, compound 4: 9.3-fold (0.97 log units) above; measured number below the stated range.
By their numbers in this assay, from the lowest: compound 4; then compounds 1 and 3 (each within the scatter of the next); then compound 2.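

In this assay, 4-carboxyphenyl to 4-methylphenyl gives a 6.7-fold lower number from compound 1 to compound 4 (0.82 log units; beyond the scatter), so the group on this aromatic carbon does move the number, and by more than the scatter. Going by these compounds alone, this is the first pair that differs in one place, and it shows something the earlier compounds could not: with the rest of the structure held fixed, this position is not indifferent to the change. No measurement shown bears on the origin of the step, which remains unexplained.

Whether the step belongs to the arrival of methyl or the departure of carboxy stays open, as the compounds shown hold no one-place pair to the unsubstituted ring. Also open, going by these compounds, is how an amine, a methoxy group or a longer chain such as ethyl on this carbon would compare with methyl in this assay.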